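This account rests on a few compounds, and the source may have more. Where it says the series, first, only, none or still open, it means among the compounds named here.

Compound 1 `COc1cccc2c1CCC2c1ncc[nH]1` gives 32 nM in a functional assay on CHO cells for agonist activity at Alpha-1A adrenergic receptor (Homo sapiens), read by FLIPR and calcium flux; a higher number here means that more compound is needed for the effect, a lower number that less compound is needed. Among the compounds with values here, compound 2 `c1cncc(-c2cccc3c2CCC3c2ncc[nH]2)c1` gives 2060 nM in this assay, the highest of the two numbers recorded; the only other compound, compound 1, sits at a lower number, the step being a 64-fold higher number from compound 1 to compound 2 (1.81 log units; beyond the scatter), brought about by pyridin-3-yl in place of methoxy on an aromatic carbon. Compound 3 `Cc1oncc1-c1cccc2c1CCC2c1ncc[nH]1` differs from compound 2 in that (5-methyl-1,2-oxazol-4-yl in place of pyridin-3-yl on an aromatic carbon). Within the data shown here, the single measured step, a 64-fold higher number from compound 1 to compound 2 (1.81 log units; beyond the scatter), bears on this only as a sign that an aromatic ring in this place, in place of methoxy, costs much in this assay; it does not separate one aromatic ring from another. Among the measured compounds shown here, no step swaps one such ring for a second, so the change from compound 2 to compound 3 is expected to stay within the scatter or to fall a little short of it. For compound 3 the value expected in this assay is 1500 nM, with a range from 400 nM to 6000 nM. That expectation amounts to a 1.4-fold lower number from compound 2 to compound 3 (0.14 log units; within the scatter).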

Compound 3, half-maximal effective concentration: 111 nM
Compound 3: the middle estimate sits 14-fold (1.13 log units) above what was measured; measured number below the stated range.
By their numbers in this assay, from the lowest: compound 1; then compound 3; then compound 2.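

At this position, an aromatic carbon ortho to a fused ring, the identity of the aromatic ring matters in this assay: the exchange of rings gives a large step (a 19-fold lower number from compound 2 to compound 3 (1.27 log units; beyond the scatter)), although the leaving and entering groups hold the same count of heavy atoms. The earlier step could be read as a cost of any aromatic ring in place of methoxy, but compound 3 narrows that cost to a modest step (a 3.5-fold higher number from compound 1 to compound 3 (0.54 log units; beyond the scatter)), so compound 1 stays lowest of the three, with both of its steps beyond the scatter. Nothing measured here accounts for the gap between the two rings.

Compound 3 changes ring size, ring oxygen and methyl group together, and its step cannot separate them. A plain phenyl ring, an unmethylated 1,2-oxazol-4-yl or an ethoxy chain at this position would bear on that question.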